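The compounds below may be only part of what the source reports. "The series", "measured", "known", "first", "only" and "open" are said of these compounds alone.

Working notes on the series. Within the data shown here, in a functional assay on the whole organism for inhibition, with Rattus norvegicus as the target, with a stated time of 5 min, at a dose of 3 mg/kg by the oral route (a lower number here means less inhibition, a higher number more inhibition at the dose given (going by the name of the read-out)), compound 3 `Cc1ccnc(C(=O)Nc2nn[nH]n2)c1` gives 51%, the lowest of the three numbers measured so far; compound 1 `CCc1ccnc(C(=O)Nc2nn[nH]n2)c1` gives 54% and compound 2 `Cc1cc(Cl)cc(C(=O)Nc2nn[nH]n2)n1` gives 85%. Among the measured compounds shown here, the only single-site step measured, a number 3 percentage points lower from compound 1 to compound 3 (within the scatter), lies within the scatter and concerns a saturated chain, not a halogen. Compound 4 `O=C(Nc1nn[nH]n1)c1cc(Cl)ccn1` differs from compound 3 by chloro in place of methyl on an aromatic carbon. For the measured compounds named here, no measured step bears directly on this exchange. Compound 2 also carries chloro and methyl and stands well above compound 3, but the two structures differ in more than one place, so that pair is no single-site guide. A modest rise is therefore expected, a number 14 percentage points higher from compound 3 to compound 4 (beyond the scatter), with wide uncertainty. Compound 4 is estimated at 65%, between 45% and 85%.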

Compound 4, a percentage reported as inhibition, in the whole organism at one dose (the size of the read-out at that dose, not a potency): 71%
Compound 4: the middle estimate sits 6 percentage points below what was measured; the measured number falls inside the stated range.
By their numbers in this assay, from the lowest: compounds 3 and 1 (each within the scatter of the next); then compound 4; then compound 2.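

In this assay the position opposite the ring nitrogen is sensitive to the group it carries, with a number 20 percentage points higher from compound 3 to compound 4 (beyond the scatter) for chloro in place of methyl and a number 17 percentage points higher from compound 1 to compound 4 (beyond the scatter) for chloro in place of ethyl. With chloro kept, the methyl of compound 2 on an aromatic carbon also counts, with a number 14 percentage points lower from compound 2 to compound 4 (beyond the scatter) for hydrogen in its place. Nothing measured on these compounds gives a reason for these steps.

The compounds shown leave open whether this rise is particular to chloro or would also appear with bromo, methoxy or an amine at this position. As far as these compounds go, whether the methyl of compound 2 adds the same amount alongside another group in place of chloro also stays open.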